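Aryl amine swap on the shared core: compound 3

The compounds below may be only part of what the source reports. "The series", "measured", "known", "first", "only" and "open" are said of these compounds alone.

Compound 1 `Cc1ccc(Nc2ncc(C(F)(F)F)c(N3Cc4cccc(N(C)S(C)(=O)=O)c4C3)n2)cc1C` and compound 2 `COc1cc(Nc2ncc(C(F)(F)F)c(N3Cc4cccc(N(C)S(C)(=O)=O)c4C3)n2)cc(C(F)(F)F)c1` share one core and differ only in the aryl on a nitrogen on an aromatic ring. In a functional assay on HepG2 cells (Homo sapiens) for antiproliferative activity, read by spectrophotometry, with a stated time of 2 days (a higher number here means a weaker inhibitor of growth, a lower number a stronger inhibitor of growth), compound 1 gives only a limit, > 30000 nM. In this assay compound 2 gives 22100 nM. The step of an at least 1.3-fold lower number from compound 1 to compound 2 (0.13 log units; that floor lies within the scatter) rests on a limit (the limit of > 30000 nM in this assay, at which 1 of the 2 values shown sits), so its true size is not known beyond the stated floor.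

Compound 3 `CN(c1cccc2c1CN(c1nc(Nc3ccc(Cl)c(C(F)(F)F)c3)ncc1C(F)(F)F)C2)S(C)(=O)=O` is not yet measured. It differs from compound 1 by 4-chloro-3-(trifluoromethyl)phenyl in place of 3,4-dimethylphenyl on a nitrogen on an aromatic ring. Going by the values given here, the only measured step that bears on this change is the one from compound 1 to compound 2, where another trifluoromethyl-bearing phenyl replaced the 3,4-dimethylphenyl at the same place and the number stayed weak. Guided by compound 2 and its value 22100 nM, compound 3 is expected to sit in the same weak region, with the step of an at least 1.5-fold lower number from compound 1 to compound 3 (0.17 log units; that floor lies within the scatter) expected to be modest at most. The estimate for compound 3 is 20000 nM, in the range 8000 nM to 40000 nM.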

Compound 3, concentration for 50% growth inhibition: 16000 nM
For compound 3 the middle estimate is 1.3-fold (0.10 log units) above the measured one; the range from low to high includes it.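

In this assay compound 3 gives 16000 nM, so 4-chloro-3-(trifluoromethyl)phenyl at this place on a nitrogen on an aromatic ring gives a second exact value on the shared core. Going by these compounds alone, this allows the first comparison at this position between two exact values, a 1.4-fold lower number from compound 2 to compound 3 (0.14 log units; within the scatter), and on this reading 3-methoxy-5-(trifluoromethyl)phenyl and 4-chloro-3-(trifluoromethyl)phenyl cannot be told apart. Compound 1 carries a limit and not a number, so an at least 1.8-fold lower number from compound 1 to compound 3 (0.27 log units; that floor lies within the scatter) fixes only a floor and leaves the true size of the change from 3,4-dimethylphenyl unknown: the limit of > 30000 nM in this assay, at which 1 of the 3 values shown sits.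

The aryl groups shown carry only methyl, methoxy, chloro and trifluoromethyl groups, so it remains open what a phenyl bearing a piperazine or a carboxylic acid would give in this assay. The rest of the shared core is constant across compound 1, compound 2 and compound 3, so these values also cannot say how a change elsewhere, such as an amine in place of the N-methyl methanesulfonamide, would read.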